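The compounds below may be only part of what the source reports. "The series", "measured", "known", "first", "only" and "open" are said of these compounds alone.

Of the compounds shown here, three sharing one core have been tested in an assay on FRT-Jurkat cells for inhibition of nuclear factor NF-kappa-B complex (Homo sapiens), read by flow cytometry, with a stated time of 24 h, tested at 10 uM; on this read-out higher numbers stand for more inhibition at the one concentration tested (going by the name of the read-out) and lower numbers for less inhibition. Compound 1 `CCCc1ccc(Nc2cccc3c2C(=O)N(C2CCC(=O)NC2=O)C3=O)cc1` carries a propyl group on its outer ring and in this assay compound 1 gives 23%. Compound 2 `CC(C)(C)c1ccc(Nc2cccc3c2C(=O)N(C2CCC(=O)NC2=O)C3=O)cc1` carries a tert-butyl group instead and compound 2 gives 36%. Compound 3 `Cc1ccc(Nc2cccc3c2C(=O)N(C2CCC(=O)NC2=O)C3=O)cc1` carries only a methyl group and compound 3 gives 9%, the lowest of the three numbers, with both other compounds sitting beyond the scatter above it.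

Compound 4 `CCCCCc1ccc(Nc2cccc3c2C(=O)N(C2CCC(=O)NC2=O)C3=O)cc1` extends the chain of compound 3: butyl in place of hydrogen on a saturated chain carbon bound to an aromatic carbon. Two measured steps speak to this kind of change. Shortening the chain gave a number 14 percentage points lower from compound 1 to compound 3 (beyond the scatter), and trading the larger tert-butyl group for methyl gave a number 27 percentage points lower from compound 2 to compound 3 (beyond the scatter). Both point the same way: the smaller group on that position went with less inhibition, and the larger groups with more. Lengthening the chain to pentyl is therefore expected to raise the number beyond the scatter, roughly to the level seen for compounds 1 and 2. Because compound 1 already reaches 23% with a shorter chain, the step is estimated as a number 21 percentage points higher from compound 3 to compound 4 (beyond the scatter). For compound 4 the expected value in this assay is 30%, within a range from 12% to 48%.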

Compound 4, a percentage reported as inhibition, at one concentration (the size of the read-out at that concentration, not a potency): 23%
Compound 4: the middle estimate sits 7 percentage points above what was measured; measured number inside the range.
By their numbers in this assay, from the lowest: compound 3; then compounds 1 and 4 (each within the scatter of the next); then compound 2.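

Lengthening methyl to pentyl in this assay gives a number 14 percentage points higher from compound 3 to compound 4 (beyond the scatter) and so shows that a chain much longer than methyl is accepted at this position without the number falling back. Among these compounds, what the earlier compounds could not show is that the gain does not keep growing with length, since the step from propyl to pentyl gives no change at the digits printed from compound 1 to compound 4 (within the scatter) and the straight chains therefore rise from methyl to propyl and then stay level at pentyl. The branched group keeps its lead, with a number 13 percentage points lower from compound 2 to compound 4 (beyond the scatter) so that, among these compounds, a longer chain does not match tert-butyl and compound 2 goes against any simple rule that a longer group means a higher number. Nothing shown here gives a measured reason for this levelling off or for the lead of the branched group.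

As far as these compounds go, it stays open whether a still longer chain such as heptyl would hold this level or lose it, and whether a branched group other than tert-butyl, such as isopropyl, would fall between methyl and tert-butyl. A chain ending in an amine or a carboxylic acid is also untested among the compounds shown, so the effect of such an end group on this read-out remains unknown.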